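Adding a Second Ethyl Group to a Secondary Amine

The source may report more compounds than this note shows. Statements on the series, on what has been measured and on what is new or still open speak of the compounds shown alone.

Compound 1 `COc1ccccc1-c1cc(CN(C)C)ccc1Cl`, 1300 nM; compound 2 `CCNCc1ccc(Cl)c(-c2ccccc2OC)c1`, 220 nM.

Both compounds were tested in an assay on isolated protein for binding affinity to 5-hydroxytryptamine receptor 1D (Homo sapiens); on this read-out lower numbers stand for stronger inhibition and higher numbers for weaker inhibition. Compound 2 stands at the lowest of the two numbers shown; its nearest neighbour is compound 1, and the step of a 5.9-fold lower number from compound 1 to compound 2 (0.77 log units; beyond the scatter) separates them, a change from dimethylamino to ethylamino on the chain carbon that carries the amine.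

Compound 3 `CCN(CC)Cc1ccc(Cl)c(-c2ccccc2OC)c1` differs from compound 2 only by ethyl in place of hydrogen on an amine nitrogen, so the amine again carries two substituents. For the measured compounds named here, the only step available, a 5.9-fold lower number from compound 1 to compound 2 (0.77 log units; beyond the scatter), runs from a doubly substituted amine to a singly substituted one and gives a lower number. Restoring a second substituent is therefore expected to move the number back up, though the groups are not identical to those of compound 1, so a smaller step is estimated: a 2.7-fold higher number from compound 2 to compound 3 (0.44 log units; beyond the scatter). Compound 3 is thus estimated at 600 nM, within 200 nM to 2000 nM.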

Compound 3, inhibition constant: > 10000 nM
Compound 3 was reported as a limit; the forecaster's own chance of this, stated with the estimate: 3%; middle value at least 16-fold (1.22 log units) away from the limit.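

In this assay, compound 3 is reported only as a limit, > 10000 nM, so its actual number is not known: the limit of > 10000 nM in this assay, at which 1 of the 3 values shown sits.

Even so, the amine nitrogen proves far less tolerant than the earlier pair could show, since adding one ethyl group gives an at least 45-fold higher number from compound 2 to compound 3 (1.65 log units; beyond the scatter). Having two substituents on the nitrogen is also not enough to fix the result. Changing both methyl groups to ethyl groups gives an at least 7.6-fold higher number from compound 1 to compound 3 (0.88 log units; beyond the scatter), so which groups sit there matters as well as how many.

On these data alone, it remains open where along this series the number begins to climb, for example with a methylamino group, a primary amine or a longer chain such as propylamino. A ring amine such as pyrrolidine, which ties the nitrogen's substituents together, could also behave differently from diethylamino.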